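Notes on amide substituent changes in the pyridine-N-oxide series

The source may report more compounds than this note shows. Statements on the series, on what has been measured and on what is new or still open speak of the compounds shown alone.

Compound 1 `O=C(CN1CCC(c2cccc[n+]2[O-])CC1)Nc1ccc(F)cc1F`, compound 2 `O=C(CN1CCC(c2cccc[n+]2[O-])CC1)NC1CCCCC1` and compound 3 `O=C(CN1CCC(c2cccc[n+]2[O-])CC1)Nc1ccc(F)cc1` share one core and differ only in the group on the amide-type nitrogen. In a functional assay on HEK293 cells for agonist activity at D(4) dopamine receptor (Homo sapiens), read by FLIPR (a higher number here means a larger maximal response, a lower number a smaller maximal response), compound 1 gives 74%, compound 2 gives 58% and compound 3 gives 71%. Compound 3 therefore stands second highest of the three numbers, with compound 1 within the scatter of it and compound 2 clearly lower.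

Compound 4 `O=C(CN1CCC(c2cccc[n+]2[O-])CC1)Nc1cccc(Cl)c1` is the next member. Its change from compound 3 is 3-chlorophenyl in place of 4-fluorophenyl on an amide-type nitrogen.

Two kinds of measured step bear on this. Swapping the ring type on the nitrogen gave a number 16 percentage points lower from compound 1 to compound 2 (beyond the scatter) and a number 13 percentage points higher from compound 2 to compound 3 (beyond the scatter), so the phenyl-bearing compounds sit together above compound 2. Within the phenyl-bearing pair, removing a fluoro gave a number 3 percentage points lower from compound 1 to compound 3 (within the scatter), a step that stayed inside the scatter. Compound 4 keeps a phenyl ring and only changes the halogen and its position, so no step beyond the scatter is expected in this assay.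

For compound 4 the expected step is a number 1 percentage points lower from compound 3 to compound 4 (within the scatter), and its value is estimated at 70%, with a range from 58% to 82%.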

Compound 4, largest response reached (reported as efficacy), in percent of the reference or control that the assay uses: 76%
The estimate for compound 4 lay 6 percentage points below the measured number; low and high end bracket the measured number.
By their numbers in this assay, from the lowest: compound 2; then compounds 3, 1 and 4 (each within the scatter of the next).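

In this assay, the exchange of 4-fluorophenyl for 3-chlorophenyl on the amide-type nitrogen gives a number 5 percentage points higher from compound 3 to compound 4 (within the scatter), and the exchange of 2,4-difluorophenyl for 3-chlorophenyl gives a number 2 percentage points higher from compound 1 to compound 4 (within the scatter), so this position accepts a different halogen at a different ring position without a step beyond the scatter. Against the cyclohexyl group, the change gives a number 18 percentage points higher from compound 2 to compound 4 (beyond the scatter), so the separation of the cyclohexyl amide from the phenyl-bearing amides now holds for three differently halogenated phenyl groups, and none of the four compounds goes against it. No supporting data on the origin of these steps are available.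

Open, on these data alone, is how an unsubstituted phenyl, a 3-fluorophenyl or a 4-chlorophenyl would read in this assay, which would separate the identity of the halogen from its place on the ring. Also open, as far as these compounds go, is whether a methoxy group, a nitrile or a carboxylic acid on the phenyl ring, or a benzyl group on the nitrogen, would keep the response with the phenyl-bearing compounds or bring it nearer to the cyclohexyl amide.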